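The source may hold more compounds than are shown below. What is called first, only, known or untested is meant among the compounds shown, and "the series" means these compounds.

Compound 1 `O=C(NNC(=S)Nc1csc(-c2ccccc2)c1)c1ccc(O)cc1` and compound 2 `Cc1ccc(-c2cc(NC(=S)NNC(=O)c3ccc(O)cc3)cs2)cc1` share one core; compound 3 `Oc1ccc(-c2nnc(Nc3csc(-c4ccccc4)c3)s2)cc1` and compound 4 `Cc1ccc(-c2cc(Nc3nnc(-c4ccc(O)cc4)s3)cs2)cc1` share another. How the two cores differ is not broken down here. In a functional assay on MCF7 cells (Homo sapiens) for inhibition, read by colorimetric assay and MTT assay, with a stated time of 72 h (a higher number here means a weaker inhibitor, a lower number a stronger inhibitor), compound 1 gives 78000 nM, and compound 2 gives 42000 nM. The change between them is methyl in place of hydrogen on an aromatic carbon, and the step it made was a 1.9-fold lower number from compound 1 to compound 2 (0.27 log units; within the scatter). In this assay compound 3 gives 24000 nM; its gap to compound 2 lies within the scatter, its gap to compound 1 beyond it. Compound 4 carries the same kind of change set on the second core: methyl in place of hydrogen on an aromatic carbon. The two place descriptions read the same word for word, so the surroundings of the change match as far as they are described. The expected step for compound 4 in this assay is a 1.7-fold lower number from compound 3 to compound 4 (0.23 log units; within the scatter). Among the measured compounds shown here, this expectation rests on the single earlier instance of the change, a 1.9-fold lower number from compound 1 to compound 2 (0.27 log units; within the scatter), which itself lay within the scatter, so the footing is thin. The estimate for compound 4 is 14000 nM, spanning 6000 nM to 32000 nM.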

Compound 4, half-maximal inhibitory concentration: 8000 nM
Beside the measured number, compound 4's estimate is 1.8-fold (0.24 log units) above it; the measured number falls inside the stated range.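

In this assay, methyl in place of hydrogen on an aromatic carbon gives a 3.0-fold lower number from compound 3 to compound 4 (0.48 log units; beyond the scatter) and so moves the number in the same direction on the core of compound 3 as on the core of compound 1. The two instances do not differ by more than repeated measurement allows: the same change on two cores in this assay, a 1.9-fold lower number (0.27 log units; within the scatter) from compound 1 to compound 2 and a 3.0-fold lower number (0.48 log units; beyond the scatter) from compound 3 to compound 4, 1.6-fold (0.21 log units) apart, within the scatter of two such steps. Among the compounds shown here, this supports carrying the change between these two cores in direction and rough size, but it rests on only two pairs, one of them within the scatter on its own, and it does not show why the number moves or whether the change would carry to any other core.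

The compounds shown hold only hydrogen or methyl at this place, so it remains open how a fluorine, a methoxy group or a longer chain such as propyl would read there. Also open, on these data alone, is what an amine or a carboxylic acid in place of the hydroxyl would do on either core.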